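Inverting One Ring Stereocentre in a Urotensin-2 Receptor Ligand

The source may report more compounds than this note shows. Statements on the series, on what has been measured and on what is new or still open speak of the compounds shown alone.

Compound 1 `Cc1ccc(C(=O)N[C@H]2CCN(Cc3ccc(OCCCN(C)C)cc3)C2)cc1C`: in an assay on HEK293 cells for binding affinity to Urotensin-2 receptor (Homo sapiens), read by radioligand binding (a lower number here means a stronger inhibitor, a higher number a weaker inhibitor), compound 1 gives only a limit, < 10000 nM.
Compound 2 `Cc1cc(C(=O)N[C@H]2CCN(Cc3ccc(OCCCN(C)C)cc3)C2)ccc1Br`: in this assay compound 2 gives 631 nM.
Compound 3 `CC(C)C[C@H](NC(=O)c1cc2ccccc2o1)C(=O)N[C@H]1CCN(Cc2ccc(OCCCN(C)C)cc2)C1`: in this assay compound 3 gives 158 nM.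

Compound 3 stands at the lowest of the two numbers in this assay; compound 2 is the nearest, higher, beyond the scatter. Within the data shown here, the single measured step, a step that the limit leaves unreadable from compound 1 to compound 2, is unreadable because compound 1 sits at the limit of < 10000 nM in this assay, at which 1 of the 3 values shown sits.

Compound 4 `CC(C)C[C@H](NC(=O)c1cc2ccccc2o1)C(=O)N[C@@H]1CCN(Cc2ccc(OCCCN(C)C)cc2)C1` differs from compound 3 in the two compounds have the same atoms and bonds and differ only in configuration as drawn: 1 of 2 stereo elements differ; a stereocentre at a saturated ring carbon is drawn S in compound 3 and R in compound 4. Among the measured compounds shown here, no measured step touches a stereocentre, so none bears on this change, and its direction in this assay cannot be read from the measured compounds. Compound 4 is therefore estimated at 800 nM, between 120 nM and 8000 nM. The expected step is a 5.1-fold higher number from compound 3 to compound 4 (0.70 log units; beyond the scatter), with wide uncertainty.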

Compound 4, inhibition constant: < 10000 nM
Compound 4: only a limit was reported; the forecaster's own chance of this, stated with the estimate: 25%; the middle value is on the limit's open side.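

No step from compound 3 to compound 4 can be read, because compound 4 gives only a limit: the limit of < 10000 nM in this assay, at which 2 of the 4 values shown sit.

Going by these compounds, whether drawing the ring stereocentre R rather than S raises or lowers the number, and by how much, stays open.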